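The compounds below may be only part of what the source reports. "The series", "measured", "known", "first", "only" and "open" are said of these compounds alone.

Compound 1 `CNC(=O)[C@@]12C[C@@H]1[C@@H](n1cnc3c(NCc4cccc(Cl)c4)nc(C#CCCCCc4cn(-c5ccc(N)cc5)nn4)nc31)[C@H](O)[C@@H]2O` is the starting point. In an assay on CHO cells for displacement of a labelled ligand from adenosine receptor A1 (Homo sapiens), read by scintillation counting, tested at 10 uM (a lower number here means less inhibition, a higher number more inhibition at the concentration tested (going by the name of the read-out)), compound 1 gives 3%, the lowest of the three numbers measured. Its nearest neighbour is compound 3 `CNC(=O)[C@@]12C[C@@H]1[C@@H](n1cnc3c(NCc4cccc(Cl)c4)nc(C#CCCCCc4cn(CCNC(C)=O)nn4)nc31)[C@H](O)[C@@H]2O`, which gives 12%; the step of a number 9 percentage points higher from compound 1 to compound 3 (within the scatter). The furthest is compound 2 `CNC(=O)[C@@]12C[C@@H]1[C@@H](n1cnc3c(NCc4cccc(Cl)c4)nc(C#CCCCCc4cn(Cc5ccc(-n6sccc6=O)cc5)nn4)nc31)[C@H](O)[C@@H]2O`, which gives 15%, a gap from compound 1 that lies beyond the scatter.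

Compound 4 `CNC(=O)[C@@]12C[C@@H]1[C@@H](n1cnc3c(NCc4cccc(Cl)c4)nc(C#CCCCCc4cn(-c5ccc(N=C=S)cc5)nn4)nc31)[C@H](O)[C@@H]2O` differs from compound 1 only at one site: a group of 3 heavy atoms (1 carbon, 1 nitrogen, 1 sulfur; no ring) in place of one nitrogen atom, on an aromatic carbon. Of the measured steps, only a number 9 percentage points higher from compound 1 to compound 3 (within the scatter) touches the same part of the molecule, the group attached to the aromatic nitrogen, and it stayed within the scatter; a number 3 percentage points lower from compound 2 to compound 3 (within the scatter) also stayed within the scatter, though it alters a different region. Neither step suggests that swapping a substituent on this outer ring moves the read-out much. For compound 4 the expected step is therefore a number 5 percentage points higher from compound 1 to compound 4 (within the scatter), nothing beyond the scatter. Compound 4 is estimated at 8%, in the range 0% to 25%.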

Compound 4, a percentage reported as inhibition, at one concentration (the size of the read-out at that concentration, not a potency): 2%
Estimate against measurement, compound 4: 6 percentage points above; the range from low to high includes it.
By their numbers in this assay, from the lowest: compounds 4, 1, 3 and 2 (each within the scatter of the next, the first and the last beyond it).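

Putting an isothiocyanate in place of the amino group, on an aromatic carbon para to a large group, gives a number 1 percentage points lower from compound 1 to compound 4 (within the scatter) in this assay at the one concentration tested, so this swap on the ring does not separate the two compounds. The larger swap on the aromatic nitrogen, a ring-bearing group in place of the open chain of compound 3, gives a number 10 percentage points lower from compound 3 to compound 4 (within the scatter) and so does not separate those two compounds either. Nothing available explains these numbers.

These readings come from a single concentration, so they do not show how either compound would behave at other concentrations. On these data alone, whether any group at this ring position could lift the inhibition remains open, and a methoxy group or a carboxylic acid in place of the amino group would be one way to ask.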